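The compounds below may be only part of what the source reports. "The series", "measured", "known", "first", "only" and "open" are said of these compounds alone.

Compounds measured so far:
- compound 1, `Cc1cc(C)cc(-c2c(O)nc3cc(Cl)c([N+](=O)[O-])cc3c2OCC[C@H]2CCCCN2)c1`: in an assay on isolated protein for inhibition of Gonadotropin-releasing hormone receptor (Rattus norvegicus) (a higher number here means a weaker inhibitor, a lower number a stronger inhibitor), compound 1 gives 10 nM
- compound 2, `Cc1cc(C)cc(-c2c(O)nc3cc(Cl)c([N+](=O)[O-])cc3c2OCC[C@@H]2Cc3ccccc3CN2)c1`: in this assay compound 2 gives 70 nM
- compound 3, `Cc1cc(C)cc(-c2c(O)nc3cc(Cl)c([N+](=O)[O-])cc3c2OCC[C@@H]2CCC[C@H](C)N2)c1`: in this assay compound 3 gives 15 nM

Compound 3 stands second highest of the three numbers: its neighbour is compound 1, with a 1.5-fold higher number from compound 1 to compound 3 (0.18 log units; within the scatter), a gap within the scatter, while the furthest is compound 2, with a 4.7-fold lower number from compound 2 to compound 3 (0.67 log units; beyond the scatter), a gap beyond the scatter. The new compound 4, `Cc1cc(C)cc(-c2c(O)nc3cc(Cl)c([N+](=O)[O-])cc3c2OCCC2NCCCC2C)c1`, differs from compound 3 only at the ring on the side chain: 3-methylpiperidin-2-yl in place of 6-methylpiperidin-2-yl on a saturated chain carbon, two bonds along the chain from an oxygen on an aromatic ring.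

Going by the values given here, no measured pair moves a methyl from one ring carbon to another, so no step speaks to this change directly. The nearest guide is a 1.5-fold higher number from compound 1 to compound 3 (0.18 log units; within the scatter), which shows that adding a methyl to the piperidine ring at one position changed the number only within the scatter. The step to compound 2 shows that a larger rebuilding of this ring does cost potency, but compound 4 keeps the same atoms and the same ring size. The step of a 1.2-fold higher number from compound 3 to compound 4 (0.08 log units; within the scatter) is therefore expected to stay within the scatter. For compound 4 the estimate in this assay is 18 nM, with a plausible range from 6 nM to 55 nM.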

Compound 4, half-maximal inhibitory concentration: 45 nM
The estimate for compound 4 lay 2.5-fold (0.40 log units) below the measured number; low and high end bracket the measured number.
By their numbers in this assay, from the lowest: compounds 1 and 3 (each within the scatter of the next); then compounds 4 and 2 (each within the scatter of the next).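

Where the methyl sits on the piperidine ring matters in this assay: with the same atoms joined differently, the change gives a 3.0-fold higher number from compound 3 to compound 4 (0.48 log units; beyond the scatter) and so goes beyond the scatter, which means the tolerance of the methyl in compound 3 does not extend to every ring carbon. Set against the unsubstituted ring, the move gives a 4.5-fold higher number from compound 1 to compound 4 (0.65 log units; beyond the scatter) as a clear loss, whereas the comparison with the rebuilt ring gives a 1.6-fold lower number from compound 2 to compound 4 (0.19 log units; within the scatter) and stays within the scatter, so moving one methyl here costs about as much as that larger rebuilding. Nothing available explains this shift.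

From the compounds shown here alone, compound 4 is drawn without defined stereocentres, unlike compound 3, so how each spatial arrangement of 3-methylpiperidin-2-yl behaves remains open. Also open, going by these compounds, is how an ethyl or a hydroxyl would fare in place of this methyl.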